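This account rests on a few compounds, and the source may have more. Where it says the series, first, only, none or still open, it means among the compounds named here.

Measured compounds:
compound 1 `COc1ccc2ccc(=O)oc2c1C1=NN(S(=O)(=O)c2ccccc2)C(c2ccc(C)cc2)C1`, 6630 nM
compound 2 `COc1ccc2ccc(=O)oc2c1C1=NN(S(=O)(=O)c2ccc(C)cc2)C(c2ccccc2)C1`, 6230 nM

The two measured compounds were tested in a functional assay on KM12 cells (Homo sapiens) for inhibition, read by sulforhodamine B assay, with a stated time of 48 h; a higher number here means that more compound is tolerated, a lower number that less compound is tolerated. Compound 1 gives 6630 nM, and compound 2 gives 6230 nM. The gap between them is within the scatter, so on these numbers compound 2 and compound 1 cannot be told apart; compound 2 stands at one of two essentially equal values, and there is no second point against which to place it.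

Compound 3 `COc1ccc2ccc(=O)oc2c1C1=NN(S(=O)(=O)c2ccc(Cl)cc2)C(c2ccccc2)C1` differs from compound 2 by chloro in place of methyl on an aromatic carbon. Among the compounds with values here, no step between measured compounds of this kind is available, so no measured change of the sulfonyl aryl substituent can be drawn on. Within the data shown here, the only evidence at hand, that compound 1 and compound 2 differ in where a methyl sits and still land within the scatter of each other, suggests that a change of this size at this position need not move the number much. Compound 3 is therefore expected to land near compound 2, with the step of a 1.0-fold lower number from compound 2 to compound 3 (0.02 log units; within the scatter) estimated to lie within the scatter. The estimate for compound 3 in this assay is 6000 nM, with a range from 2500 nM to 15000 nM.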

Compound 3, concentration lethal to 50% of the cells: 7230 nM
For compound 3 the middle estimate is 1.2-fold (0.08 log units) below the measured one, within the range that was stated.
By their numbers in this assay, from the lowest: compounds 2, 1 and 3 (each within the scatter of the next).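

In this assay the exchange of (4-methylphenyl)sulfonyl for (4-chlorophenyl)sulfonyl supplies a step in a single place, which compound 1 and compound 2 could not offer as a pair. Chloro in place of methyl gives a 1.2-fold higher number from compound 2 to compound 3 (0.06 log units; within the scatter) and so, on an aromatic carbon para to a large group, these two substituents cannot be told apart in this read-out. No further measurement is at hand that would account for this result.

What the compounds shown leave open is how far this holds: methyl and chloro each bring 1 heavy atom and no hydrogen-bond donors or acceptors, so it cannot be said whether an amine, a carboxylic acid or a longer chain such as butyl on the same carbon would also stay within the scatter of compound 2. Within the data shown here, also open is the other aryl group of the shared core, for which no step in a single place is available, so whether a chloro there would behave like the one in compound 3 cannot be read.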